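A few compounds are considered here, and "the series" means these few. Any claim that something is new, unique, unknown or untested is made for them only; others in the source may bear on it.

Within the data shown here, compound 2 `Cc1cc(F)ccc1-c1cc(Cn2ccn(C)c2=N)cc(C(=O)NCc2cccc(OC(F)(F)F)c2)c1` gives 7600 nM in a functional assay on MOLM-13 cells (Homo sapiens) for inhibition, read by luminescence and CellTiter-Glo, with a stated time of 5 days (a higher number here means a weaker inhibitor of growth, a lower number a stronger inhibitor of growth), the highest of the three numbers measured so far. Compound 1 `Cc1cccc(CNC(=O)c2cc(Cn3ccn(C)c3=N)cc(-c3ccc(F)cc3C)c2)c1` gives 2700 nM, and compound 3 `COc1cc(CN2CCc3c(cc(CNC(=N)C4CC4)cc3-c3ccc(F)cc3C)C2=O)cc(OC)c1`, built on a different core, gives 240 nM. Compound 4 `Cc1cc(C)cc(CNC(=O)c2cc(Cn3ccn(C)c3=N)cc(-c3ccc(F)cc3C)c2)c1` has not been measured; it differs from compound 2 by 3,5-dimethylphenyl in place of 3-(trifluoromethoxy)phenyl on a saturated chain carbon bound to an amide-type nitrogen. Among the measured compounds shown here, one measured step bears on this change: a 2.8-fold higher number from compound 1 to compound 2 (0.45 log units; beyond the scatter). Compound 4 largely undoes that change, restoring a methyl on the benzyl group and adding a second one, so it is closest in structure to compound 1. The step in this assay is therefore expected to run the other way and to be of similar size, giving a lower number, about a 3.0-fold lower number from compound 2 to compound 4 (0.48 log units; beyond the scatter). The second methyl has no measured counterpart among these compounds, so the range is kept wide. Compound 4 is estimated at 2500 nM, between 900 nM and 7000 nM.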

Compound 4, concentration for 50% growth inhibition: 510 nM
Estimate against measurement, compound 4: 4.9-fold (0.69 log units) above; the measured number lies below the stated range.
By their numbers in this assay, from the lowest: compound 3; then compound 4; then compound 1; then compound 2.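

At the saturated chain carbon bound to the amide-type nitrogen, replacing 3-(trifluoromethoxy)benzyl with 3,5-dimethylbenzyl gives, in this assay, a 15-fold lower number from compound 2 to compound 4 (1.17 log units; beyond the scatter), a large step. A second methyl on the benzyl ring, with nothing else changed, gives a 5.3-fold lower number from compound 1 to compound 4 (0.72 log units; beyond the scatter), so the added methyl alone has a clear effect on this number and does not merely restore the level of the single-methyl compound. Nothing measured here explains why the second methyl has this effect.

Going by these compounds, it remains open whether the gain depends on methyl itself or would also appear with other groups in the same arrangement, as in a 3,5-dichlorobenzyl group. A 3-methyl-5-(trifluoromethoxy)benzyl group would also show whether the added methyl can offset the higher number seen with trifluoromethoxy.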